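From methylamino to 2-methoxyphenyl on the shared core

The source may report more compounds than this note shows. Statements on the series, on what has been measured and on what is new or still open speak of the compounds shown alone.

In a physicochemical assay for solubility, measured as kinetic solubility (on this read-out lower numbers stand for lower solubility and higher numbers for higher solubility), compound 2 `CNc1ccnc2c(O)c(-c3nc(C)n[nH]3)ncc12` gives > 250000 nM, which is a limit of the assay and not a number. Compound 1 `Oc1c(-c2nc(C(O)c3ccccc3)n[nH]2)ncc2cccnc12` gives > 250000 nM, which is also a limit. Compound 3 `Cc1n[nH]c(-c2ncc3c(NCc4ccc(Cl)cc4)ccnc3c2O)n1` gives a true number, 219000 nM.

Compound 4 `COc1ccccc1-c1ccnc2c(O)c(-c3nc(C)n[nH]3)ncc12` carries 2-methoxyphenyl in place of methylamino on an aromatic carbon, opposite the ring nitrogen: 2-methoxyphenyl in place of methylamino on an aromatic carbon. Going by the values given here, only one measured step bears on this change, an at least 1.1-fold lower number from compound 2 to compound 3 (0.05 log units; that floor lies within the scatter). It adds 4-chlorophenyl on the chain carbon and keeps the nitrogen, whereas the new change replaces the whole methylamino group, so it is only a loose guide. With compound 3 still at 219000 nM, a modest fall is expected in this assay, though it may not clear the scatter by much. The expected step is an at least 2.0-fold lower number from compound 2 to compound 4 (0.31 log units; beyond the scatter). For compound 4 the estimated value is 120000 nM, with an expected range from 35000 nM to 250000 nM.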

Compound 4, solubility: > 250000 nM
Compound 4: only a limit was reported (the forecaster's own chance of this, stated with the estimate: 20%); middle value at least 2.0-fold (0.31 log units) away from the limit.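

In this assay, compound 2 and compound 4 both stand at a limit and not at a number, so no step between them can be read: the limit of > 250000 nM in this assay, at which 3 of the 4 values shown sit.

The compounds shown leave open whether 2-methoxyphenyl in place of methylamino on an aromatic carbon changes the read-out at all.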